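Methyl in Place of Hydrogen on an Aromatic Carbon

A few compounds are considered here, and "the series" means these few. Any claim that something is new, unique, unknown or untested is made for them only; others in the source may bear on it.

Measured in a functional assay on CHO cells for positive allosteric modulation of metabotropic glutamate receptor 2 (Homo sapiens), read by scintillation counting and GTPgammaS binding, with a stated time of 30 min; on this read-out lower numbers stand for an effect already at smaller amounts and higher numbers for an effect only at larger amounts of compound:
compound 1 `Cc1ncccc1Oc1ccc(-c2ccn(CCC(C)C)c(=O)c2C#N)cc1`: 275 nM
compound 2 `Cc1ccc(Oc2ccc(-c3ccn(CCC(C)C)c(=O)c3C#N)cc2)c(C)n1`: 100 nM
compound 3 `CCCCn1ccc(-c2ccc(Oc3cccnc3C)c(Cl)c2)c(C#N)c1=O`: 100 nM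

From compound 1 to compound 2 the change is methyl in place of hydrogen on an aromatic carbon, and it gave a 2.8-fold lower number from compound 1 to compound 2 (0.44 log units; beyond the scatter). Compound 3 stands level with compound 2 at the digits reported, and these two share the lowest numbers of the three. Compound 3 differs from compound 1 in more than one place, and the difference between the two cores is not broken down here.

Compound 4 `CCCCn1ccc(-c2ccc(Oc3ccc(C)nc3C)c(Cl)c2)c(C#N)c1=O` has not yet been measured. It differs from compound 3 by methyl in place of hydrogen on an aromatic carbon, the same change that separates compound 1 from compound 2. Compound 4 is therefore expected to show a 2.2-fold lower number from compound 3 to compound 4 (0.35 log units; beyond the scatter), resting on a 2.8-fold lower number from compound 1 to compound 2 (0.44 log units; beyond the scatter). The estimate for compound 4 is 45 nM, expected to fall between 20 nM and 120 nM.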

Compound 4, half-maximal effective concentration: 30 nM
Compound 4: the middle estimate sits 1.5-fold (0.18 log units) above what was measured; low and high end bracket the measured number.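

In this assay the change from 2-methylpyridin-3-yl to 2,6-dimethylpyridin-3-yl gave a 3.3-fold lower number from compound 3 to compound 4 (0.52 log units; beyond the scatter). Set beside the earlier step, the change carried from one core to the other at much the same size: the same change on two cores in this assay, a 2.8-fold lower number (0.44 log units; beyond the scatter) from compound 1 to compound 2 and a 3.3-fold lower number (0.52 log units; beyond the scatter) from compound 3 to compound 4, 1.2-fold (0.08 log units) apart, within the scatter of two such steps. Among the compounds shown here, these are only two pairs in one assay; they do not show that the step would hold on further cores, and they give no cause for it.

The compounds shown leave open whether an ethyl group, a methoxy group or an amine in place of the new methyl, next to the ring nitrogen, would give a step of like size. Also open, going by these compounds, is whether the step persists when a longer chain is carried on the core.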